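Changing a Side Chain While Watching Cell Tolerance

The source may hold more compounds than are shown below. What is called first, only, known or untested is meant among the compounds shown, and "the series" means these compounds.

Of the compounds shown here, three of a shared core have been tested in an ADME assay on HepG2 2.2.15 cells (Homo sapiens) for cytotoxicity; a higher number here means that more compound is tolerated, a lower number that less compound is tolerated. Compound 1 `CC(C)(C)OC(=O)Nc1ncc(C(Oc2ccc(Cc3ccccc3)cc2)c2ccc(Cl)cc2)s1` gives > 50000 nM, which is a limit of the assay rather than a number. Compound 2 `Cc1ccc(COC(c2ccccc2)c2cnc(NC(=O)c3cccs3)s2)cc1` is reported in this assay as "not toxic" (no number reported). Compound 3 `COCCNc1ncc(C(Oc2ccc3cc(Br)ccc3c2)c2ccc(Cl)cc2)s1` likewise shows "not toxic" (no number reported) in this assay, so it stands among the compounds without a measured number. Among the three values, the only numeric entry is the limit of > 50000 nM in this assay, at which 1 of the 3 values shown sits. Compound 4 `N#Cc1cccc(C(=O)Nc2ncc(C(Oc3ccc4cc(Br)ccc4c3)c3ccc(Cl)cc3)s2)c1` differs from compound 3 by (3-cyanophenyl)carbonyl in place of 2-methoxyethyl on a nitrogen on an aromatic ring. Among the measured compounds shown here, with no measured step between two compounds to draw on, the change is expected to leave tolerance within the usual scatter, with no direction to call. Compound 4 is therefore estimated in this assay at 60000 nM, in a range from 20000 nM to 200000 nM.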

Compound 4, half-maximal cytotoxic concentration: > 50000 nM
Compound 4: no number, only a limit; the forecaster's own chance of this, stated with the estimate: 80%; the middle value does not contradict the limit.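

Compound 3 has no number and compound 4 shows only a limit, so no step can be read between them. What changing the side chain on the nitrogen does to tolerance in this assay stays open, with values stopping at a limit: the limit of > 50000 nM in this assay, at which 2 of the 4 values shown sit.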